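An Isopropyl Added to Compound 2

A few compounds are considered here, and "the series" means these few. Any claim that something is new, unique, unknown or untested is made for them only; others in the source may bear on it.

Going by the values given here, compound 2 `CCn1c(C(=O)NCC(=O)O)ccc1C(CC)(CC)c1ccc(C#CC(O)(CC)CC)c(C)c1` is the only member of this set with a number in an assay on cells for agonist activity at vitamin D3 receptor (Homo sapiens), read by microscopy (on this read-out higher numbers stand for an effect only at larger amounts of compound and lower numbers for an effect already at smaller amounts), where compound 2 gives 9.36 nM. Compound 1 `CCn1c(C(=O)On2nnc3ccccc32)ccc1C(CC)(CC)c1ccc(C#CC(O)(CC)CC)c(C)c1` reaches only a limit there, > 50 nM. The step of an at least 5.3-fold lower number from compound 1 to compound 2 (0.72 log units; beyond the scatter) rests on that limit of > 50 nM in this assay, at which 1 of the 2 values shown sits, and concerns a change on the carbonyl carbon, not the place now considered. Compound 3 `CCn1c(C(=O)N[C@H](C(=O)O)C(C)C)ccc1C(CC)(CC)c1ccc(C#CC(O)(CC)CC)c(C)c1` differs from compound 2 by isopropyl in place of hydrogen on a saturated chain carbon bound to an amide-type nitrogen and a carbonyl carbon. Among the compounds with values here, no measured step touches this place, so compound 3 is expected to stay within the scatter of compound 2, an expected step of a 1.1-fold higher number from compound 2 to compound 3 (0.03 log units; within the scatter). Compound 3 is estimated at 10 nM, between 3 nM and 35 nM.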

Compound 3, half-maximal effective concentration: 17.7 nM
Beside the measured number, compound 3's estimate is 1.8-fold (0.25 log units) below it, and the stated range covers the measured number.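

In this assay, the first change shown at this saturated chain carbon, bound to an amide-type nitrogen and a carbonyl carbon, gives a 1.9-fold higher number from compound 2 to compound 3 (0.28 log units; within the scatter), so isopropyl and hydrogen cannot be told apart here. The carboxylic acid and the amide-type nitrogen are present in both compounds, and this place accepts the added isopropyl without a step beyond the scatter. The other new step, an at least 2.8-fold lower number from compound 1 to compound 3 (0.45 log units; beyond the scatter), concerns the carbonyl carbon and rests on the limit of compound 1: the limit of > 50 nM in this assay, at which 1 of the 3 values shown sits.

Only hydrogen and isopropyl are shown at this place. On these data alone, what a benzyl group, a hydroxymethyl group or a longer chain would do there stays open.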